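Phenyl in place of methyl on a pyrazolopyridinone core

The compounds below may be only part of what the source reports. "The series", "measured", "known", "first", "only" and "open" are said of these compounds alone.

Compound 1 `Cc1cc2[nH]nc(N)c2c(=O)[nH]1` gives 30% in an assay on isolated protein for inhibition of MAP kinase-activated protein kinase 2 (Homo sapiens), read by mobility shift assay, tested at 30 uM; a higher number here means more inhibition at the concentration tested (going by the name of the read-out), a lower number less inhibition. Compound 2 `Cc1cc2c(c(N)nn2C)c(=O)[nH]1` carries a methyl in place of hydrogen on an aromatic nitrogen and gives 29% in this assay. Compound 2 therefore stands essentially level with compound 1, as the step of a number 1 percentage points lower from compound 1 to compound 2 (within the scatter) shows. Compound 3 `Cn1nc(N)c2c(=O)[nH]c(-c3ccccc3)cc21` differs from compound 2 by phenyl in place of methyl on an aromatic carbon. For the measured compounds named here, the only measured step, the methylation from compound 1 to compound 2, is a different kind of change and offers no direct guide to the exchange of methyl for phenyl; it shows only that the inhibition in this assay is level across that small change, within the scatter. Compound 3 is thus expected to give about 32%, with a range from 10% to 60%. This expectation corresponds to an estimated step of a number 3 percentage points higher from compound 2 to compound 3 (within the scatter), with wide uncertainty.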

Compound 3, a percentage reported as inhibition, at one concentration (the size of the read-out at that concentration, not a potency): 37%
The estimate for compound 3 lay 5 percentage points below the measured number; the range from low to high includes it.
By their numbers in this assay, from the lowest: compounds 2, 1 and 3 (each within the scatter of the next).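

The step of a number 8 percentage points higher from compound 2 to compound 3 (within the scatter) shows that this aromatic carbon, next to the ring nitrogen, takes a phenyl in place of a methyl with no change beyond the scatter in this assay. The earlier compounds had shown such a level result only for a methyl on an aromatic nitrogen, whereas here it holds on an aromatic carbon and for a group of more heavy atoms, with a ring of its own. Nothing at hand offers a reason for this level result.

On these data alone, it remains open whether another group on this carbon, such as an amine, a carboxylic acid or a longer chain, would move the number in this assay beyond the scatter. As far as these compounds go, it also remains open whether phenyl would give the same result on the core of compound 1, with hydrogen on the aromatic nitrogen.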